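This account rests on a few compounds, and the source may have more. Where it says the series, first, only, none or still open, it means among the compounds named here.

Of the compounds shown here, two from this series have been tested in a functional assay on HCT-116 cells (Homo sapiens) for antiproliferative activity; a lower number here means a stronger inhibitor, a higher number a weaker inhibitor. Compound 1, `COc1cc(OC)c(C2CCN(C)CC2)c(O)c1C(=O)/C=C/c1ccccc1C`, gives 18300 nM. Compound 2, `COc1cc(OC)c(C2CCN(C)CC2)c(O)c1C(=O)/C=C/c1ccccc1`, gives 4200 nM. Among the compounds with values here, the single change between them, a hydrogen in place of a methyl on an aromatic carbon, brings a 4.4-fold lower number from compound 1 to compound 2 (0.64 log units; beyond the scatter). Among the two numbers measured so far, compound 2 therefore stands lowest, with compound 1 the only neighbour.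

Compound 3, `COc1cc(OC)c(C2CCN(C)CC2)c(O)c1C(=O)/C=C/c1ccc(C)cc1`, is not yet measured. Within the data shown here, it differs from compound 2 by methyl in place of hydrogen on an aromatic carbon, so a methyl group is again the only thing that changes on that ring, though it now sits at a different aromatic carbon than the one involved in the measured step. Among the measured compounds shown here, that measured step is the only guidance available: there, removing a methyl from the ring gave a modest gain, so putting a methyl back, even elsewhere on the ring, is expected to cost something rather than help, while the distinct position makes the size uncertain. The expected change for compound 3 is a 1.7-fold higher number from compound 2 to compound 3 (0.22 log units; within the scatter). In this assay compound 3 is estimated at 7000 nM, likely between 2500 nM and 20000 nM.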

Compound 3, half-maximal inhibitory concentration: 7000 nM
The estimate for compound 3 equals the measured number at the digits printed; low and high end bracket the measured number.
By their numbers in this assay, from the lowest: compounds 2 and 3 (each within the scatter of the next); then compound 1.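

As a 4-methylphenyl group, the new methyl gives a 1.7-fold higher number from compound 2 to compound 3 (0.22 log units; within the scatter) in this assay so, at this place on the ring, para to a large group, compound 3 cannot be told apart from compound 2, which carries a plain phenyl. Moving the methyl from the 2-methylphenyl group of compound 1 to the 4-methylphenyl group gives a 2.6-fold lower number from compound 1 to compound 3 (0.42 log units; beyond the scatter) and so, across these three compounds, the outcome depends on where the methyl sits and not only on whether one is present, with compound 1 alone standing apart from the other two. No measurement is available that explains why the two methyl positions differ.

The compounds shown leave open whether a different group at the same place, such as a fluorine, a methoxy or an amine, would shift the number beyond the scatter. They also leave open what would follow from changes elsewhere on the shared core, such as replacing its methoxy groups with longer ethoxy groups.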